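Cyano in place of hydrogen: compound 3 to compound 4

The source may hold more compounds than are shown below. What is called first, only, known or untested is meant among the compounds shown, and "the series" means these compounds.

Three compounds have numbers in an assay on HEK293 cells for inhibition of SCN8A/SCN1B (Homo sapiens), read by patch clamp, with a stated time of 20 min; a higher number here means a weaker inhibitor, a lower number a stronger inhibitor. Compound 1 `CC[C@H](Nc1ccc(S(=O)(=O)Nc2nccs2)cc1)c1ccccc1` gives 1770 nM. Compound 2 `C[C@H](Nc1cc(F)c(S(=O)(=O)Nc2nccs2)cc1Cl)c1ccc(F)cc1` gives 230 nM in this assay. Compound 3 `C[C@H](Nc1cc(F)c(S(=O)(=O)Nc2cscn2)c(F)c1)c1ccccc1F` gives 60 nM in this assay, the lowest of the three numbers; its gaps to compound 2 and to compound 1 both lie beyond the scatter. Compound 4 `C[C@H](Nc1cc(F)c(S(=O)(=O)Nc2cscn2)c(F)c1)c1cc(C#N)ccc1F` has not been measured. It differs from compound 3 by cyano in place of hydrogen on an aromatic carbon. Among the measured compounds shown here, no pair of measured compounds differs in one place, so no step of this kind is known here. The change adds little, and the step is expected to stay within the scatter or to move modestly toward a lower number. Compound 4 is expected to give 50 nM, with a range from 20 nM to 150 nM. The step expected this way reads a 1.2-fold lower number from compound 3 to compound 4 (0.08 log units; within the scatter).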

Compound 4, half-maximal inhibitory concentration in the SCN8A/SCN1B assay: 140 nM
The estimate for compound 4 lay 2.8-fold (0.45 log units) below the measured number, and the stated range covers the measured number.
By their numbers in the SCN8A/SCN1B assay, from the lowest: compound 3; then compounds 4 and 2 (each within the scatter of the next); then compound 1.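

Among the compounds shown here, in the SCN8A/SCN1B assay cyano in place of hydrogen, para to the fluoro group, gives a 2.3-fold higher number from compound 3 to compound 4 (0.37 log units; beyond the scatter) and so marks this aromatic carbon as a place where the added group carries a modest cost, the first single-change reading. The same change also lowers the distribution coefficient in a physicochemical assay for lipophilicity, read by LC-MS, in phosphate buffer, measured as octanol-water partition, with a stated time of 1 h, at pH 7.4; on this read-out higher numbers stand for higher lipophilicity and lower numbers for lower lipophilicity: the measured distribution coefficient of compound 3, 2.9, and of compound 4, 2.2, a number 0.70 log units lower (beyond the scatter). In the physicochemical assay compound 3 gives 2.9 and compound 4 gives 2.2.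

One pair cannot tell whether the two shifts are linked. From the compounds shown here alone, whether an amine or a methoxy group on this carbon, or cyano elsewhere on this ring, would behave differently stays open.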